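Removing the benzoyl cap from an inactive amide

A few compounds are considered here, and "the series" means these few. Any claim that something is new, unique, unknown or untested is made for them only; others in the source may bear on it.

Of the compounds shown here, three sharing one core have been tested in a functional assay on HCT-116 cells (Homo sapiens) for cytotoxicity, read by MTT assay, with a stated time of 72 h; on this read-out higher numbers stand for weaker inhibition and lower numbers for stronger inhibition. Compound 1 `O=C(NCc1ccc(F)cc1)c1nc(Br)c2cccnc2c1NCc1ccccc1` gives in this assay a reading of > 20000 nM, which is a limit of the assay and not a number. Compound 2 `NCCCNc1c(C(=O)NCc2ccc(F)cc2)ncc2cccnc12` gives in this assay a reading of > 10000 nM, again a limit. Compound 3 `O=C(NCCCNc1c(C(=O)NCc2ccc(F)cc2)nc(Br)c2cccnc12)c1ccccc1` gives in this assay a reading of > 10000 nM, also a limit. Among the measured compounds shown here, the single change from compound 1 to compound 3 is therefore a step that the two limits leave unreadable from compound 1 to compound 3, and its size cannot be read. Compound 3 thus stands only at a limit, as do the other two values shown.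

Compound 4 `NCCCNc1c(C(=O)NCc2ccc(F)cc2)nc(Br)c2cccnc12` differs from compound 3 by hydrogen in place of benzoyl on an amine nitrogen. For the measured compounds named here, no measured step shows what this change does here, since all three values sit at limits, namely the limit of > 10000 nM in this assay, at which 2 of the 3 values shown sit, and (the limit of > 20000 nM in this assay, at which 1 of the 3 values shown sits). Compound 4 is therefore expected to show no step beyond the scatter, a step that the limit leaves unreadable from compound 3 to compound 4, in this assay. For compound 4 the estimate in this assay is 15000 nM, between 5000 nM and 60000 nM, and most likely only a limit will again be reported.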

Compound 4, half-maximal inhibitory concentration: > 20000 nM
Compound 4 gave a limit, no number (the forecaster's own chance of this, stated with the estimate: 80%); middle value at least 1.3-fold (0.12 log units) from the limit.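

In this assay compound 4 gives > 20000 nM, a limit of the assay and not a number. Among the compounds shown here, compound 1, compound 2 and compound 3 also stand at limits, so no step to compound 4 can be read. The compounds shown leave open whether any of these changes alters cytotoxicity at all.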